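The source may report more compounds than this note shows. Statements on the series, on what has been measured and on what is new or still open speak of the compounds shown alone.

Compound 1 `CC1=C(C(=O)Nc2ccc(F)cc2)C(c2ccc([N+](=O)[O-])cc2)N=C(SCc2cccc(Cl)c2)N1` gives 4.1% in a functional assay on the whole organism (artery, strain albino) with Rattus norvegicus as the target, with a stated time of 30 min, at a dose of 10 mg/kg by the oral route; a higher number here means more inhibition at the dose given (going by the name of the read-out), a lower number less inhibition. Compound 2 `CC1=C(C(=O)Nc2ccc(F)cc2)C(c2ccc([N+](=O)[O-])cc2)N=C(SCc2ccc(F)cc2)N1` gives 5.7%. Compound 3 `CC1=C(C(=O)Nc2ccc(Br)cc2)C(c2ccc(Cl)cc2Cl)N=C(SCc2ccccc2)N1` gives 3.6%.

All three numbers sit close together: compound 3 lies within the scatter of compound 1 and of compound 2 alike, so nothing separates them beyond repeat-measurement noise.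

Compound 4 `CC1=C(C(=O)Nc2ccc(Br)cc2)C(c2ccc(Cl)cc2Cl)N=C(SCc2ccccc2Cl)N1` differs from compound 3 by chloro in place of hydrogen on an aromatic carbon. For the measured compounds named here, the only measured step in this region of the molecule, a number 1.6 percentage points higher from compound 1 to compound 2 (within the scatter), exchanged one halogenated benzyl group on the sulfur for another and stayed within the scatter. On that basis, no step beyond the scatter is expected from compound 3 to compound 4, and a number 0.9 percentage points higher from compound 3 to compound 4 (within the scatter) is the estimate. Compound 4 is therefore expected to give about 4.5%, between 0% and 14%, in this assay.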

Compound 4, a percentage reported as inhibition, in the whole organism at one dose (the size of the read-out at that dose, not a potency): 5.7%
Estimate against measurement, compound 4: 1.2 percentage points below; measured number inside the range.
By their numbers in this assay, from the lowest: compounds 3, 1, 2 and 4 (each within the scatter of the next).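

In this assay, chloro in place of hydrogen on this aromatic carbon, ortho to a large group, gives a number 2.1 percentage points higher from compound 3 to compound 4 (within the scatter). The earlier step only exchanged one halogenated benzyl group for another, whereas this one compares 2-chlorobenzyl with plain benzyl and shows that adding the halogen here does not move the read-out beyond the scatter. No measurement offers an explanation for this result.

As far as these compounds go, it remains open whether an amine or a carboxylic acid at this position, or a longer chain in place of benzyl, would give a step beyond the scatter.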